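Methoxy to Hydroxy on a Urea-Bearing Antiproliferative Scaffold

This account rests on a few compounds, and the source may have more. Where it says the series, first, only, none or still open, it means among the compounds named here.

Compound 1 `COc1cc(-c2nn(-c3ccc(NC(=O)Nc4cc(C(F)(F)F)cc(C(F)(F)F)c4)cc3)cc2-c2ccncc2)ccc1Cl` was assessed in a functional assay on LOX IMVI cells (Homo sapiens) for antiproliferative activity, read by sulforhodamine B assay, with a stated time of 48 h (on this read-out lower numbers stand for stronger inhibition and higher numbers for weaker inhibition), where compound 1 gives 1630 nM. Two related compounds have been run in this assay as well: compound 3 `O=C(Nc1ccc(-n2cc(-c3ccncc3)c(-c3ccc(Cl)c(O)c3)n2)cc1)Nc1ccc(Cl)c(C(F)(F)F)c1` gives 1440 nM, and compound 2 `COc1cc(-c2nn(-c3ccc(NC(=O)c4ccc(Cl)c(Cl)c4)cc3)cc2-c2ccncc2)ccc1Cl` gives 2760 nM; both gaps from compound 1 fall within the usual scatter, so the three cannot be ranked. Compound 4 `O=C(Nc1ccc(-n2cc(-c3ccncc3)c(-c3ccc(Cl)c(O)c3)n2)cc1)Nc1cc(C(F)(F)F)cc(C(F)(F)F)c1` remains unmeasured. It differs from compound 1 by hydrogen in place of methyl on an oxygen on an aromatic ring, turning the methoxy into a hydroxy. Within the data shown here, no measured pair isolates this change; compound 3 already carries the hydroxy and gives 1440 nM, close to compound 1. The step is therefore expected to stay within the scatter, a 1.2-fold lower number from compound 1 to compound 4 (0.07 log units; within the scatter). Compound 4 is estimated at 1400 nM, ranging from 600 nM to 3300 nM.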

Compound 4, half-maximal inhibitory concentration: 1630 nM
Compound 4: middle estimate off by 1.2-fold (0.07 log units), on the low side, within the range that was stated.
By their numbers in this assay, from the lowest: compounds 3, 1, 4 and 2 (each within the scatter of the next).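

In this assay, among these compounds, hydrogen in place of methyl on the oxygen gives no change at the digits printed from compound 1 to compound 4 (within the scatter), the first reading of this change on its own, with the rest of the structure held fixed. At this place on the urea-bearing scaffold, then, methoxy and hydroxy cannot be told apart in this assay. No measurement shown here offers an explanation for this result.

As far as these compounds go, whether an amine or an ethoxy in the same place would read alike stays open. So does whether the step would hold on the amide of compound 2.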